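The compounds below may be only part of what the source reports. "The series", "measured", "known", "first", "only" and "open" are said of these compounds alone.

Compound 1 `CCNCC(=O)Nc1cc(OC)ccc1C(=O)c1ccc(OC)c2c1C=CC(C)(C)O2` gives 7230 nM in a functional assay on MCF7 cells (Homo sapiens) for antiproliferative activity, read by MTT assay, with a stated time of 48 h; a higher number here means a weaker inhibitor, a lower number a stronger inhibitor. Compound 2 `COc1ccc(C(=O)c2ccc(OC)c3c2C=CC(C)(C)O3)c(NC(=O)CN(C)C)c1` differs from compound 1 by dimethylamino in place of ethylamino on a saturated chain carbon bound to a carbonyl carbon; in this assay compound 2 gives 6530 nM, and the step of a 1.1-fold lower number from compound 1 to compound 2 (0.04 log units; within the scatter) lies within the scatter. Compound 3 `C=C(c1ccc(OC)cc1NC(=O)CNCC)c1ccc(OC)c2c1C=CC(C)(C)O2` carries a different core; the difference between the two cores is not broken down here. In this assay compound 3 gives 2920 nM, the lowest of the three numbers, with compound 2 nearest and beyond the scatter. Compound 4 `C=C(c1ccc(OC)cc1NC(=O)CN(C)C)c1ccc(OC)c2c1C=CC(C)(C)O2` is not yet measured; it differs from compound 3 by dimethylamino in place of ethylamino on a saturated chain carbon bound to a carbonyl carbon, at the same place as before, so this is the same change as from compound 1 to compound 2. The step to compound 4 is expected to be about a 1.1-fold lower number from compound 3 to compound 4 (0.03 log units; within the scatter), resting on the flat step a 1.1-fold lower number from compound 1 to compound 2 (0.04 log units; within the scatter). Compound 4 is therefore expected near 2700 nM, likely between 1400 nM and 5500 nM.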

Compound 4, half-maximal inhibitory concentration: 2580 nM
Beside the measured number, compound 4's estimate is 1.0-fold (0.02 log units) above it; the range from low to high includes it.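

In this assay, dimethylamino in place of ethylamino on a saturated chain carbon bound to a carbonyl carbon also stays within the scatter on the core of compound 3 (a 1.1-fold lower number from compound 3 to compound 4 (0.05 log units; within the scatter)). The change therefore behaves alike on both cores: the same change on two cores in this assay, a 1.1-fold lower number (0.04 log units; within the scatter) from compound 1 to compound 2 and a 1.1-fold lower number (0.05 log units; within the scatter) from compound 3 to compound 4, 1.0-fold (0.01 log units) apart, within the scatter of two such steps
This is agreement between two flat steps on two cores only; it does not show that the change would stay flat on any further core or in another assay, nor that a step of clear size would carry over from one core to another.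

Open, as far as these compounds go, is whether a primary amine, a ring amine such as morpholine or piperidine, or a longer chain in this place would move the number on either core. Also open, from the compounds shown here alone, is whether any such group would behave alike on both cores.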